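The source may report more compounds than this note shows. Statements on the series, on what has been measured and on what is new or still open speak of the compounds shown alone.

Three compounds share one core and differ only in the group attached to the amine nitrogen. In an assay on brain for displacement of a labelled ligand from D(3) dopamine receptor (Rattus norvegicus) (a lower number here means a stronger inhibitor, a higher number a weaker inhibitor), compound 1 `CCCN(CC[C@H]1CC[C@H](NC(=O)/C=C/c2ccc(F)cc2)CC1)[C@H]1CCc2nc(N)sc2C1` gives 1 nM, compound 2 `CCCN(CC[C@H]1CC[C@H](NS(=O)(=O)c2cccc3ccccc23)CC1)[C@H]1CCc2nc(N)sc2C1` gives 1.5 nM, and compound 3 `CCCN(CC[C@H]1CC[C@H](NS(=O)(=O)c2ccccc2)CC1)[C@H]1CCc2nc(N)sc2C1` gives 0.79 nM, the lowest of the three numbers, although its gaps to compound 1 and to compound 2 both lie within the scatter. Compound 4 `CCCN(CC[C@H]1CC[C@H](NS(=O)(=O)c2cccc(C)c2)CC1)[C@H]1CCc2nc(N)sc2C1` differs from compound 3 by methyl in place of hydrogen on an aromatic carbon. Within the data shown here, no measured step adds a methyl to an aromatic ring, so the nearest guides are a 1.3-fold lower number from compound 1 to compound 3 (0.10 log units; within the scatter) and a 1.9-fold lower number from compound 2 to compound 3 (0.28 log units; within the scatter), which show that even larger exchanges of the group on the amine nitrogen hardly moved this assay. A small step is therefore expected, with a 1.0-fold higher number from compound 3 to compound 4 (0.01 log units; within the scatter). For compound 4 the estimated value in this assay is 0.8 nM, expected to lie between 0.35 nM and 2 nM.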

Compound 4, inhibition constant: 0.89 nM
Beside the measured number, compound 4's estimate is 1.1-fold (0.05 log units) below it; measured number inside the range.
By their numbers in this assay, from the lowest: compounds 3, 4, 1 and 2 (each within the scatter of the next).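

In this assay, among these compounds, the earlier steps swapped the whole group on the amine nitrogen, whereas this one changes the phenyl ring itself: a 1.1-fold higher number from compound 3 to compound 4 (0.05 log units; within the scatter) shows that a methyl on an aromatic carbon, meta to a large group, leaves the number within the scatter. The new compound also stays close to the other two, with a 1.7-fold lower number from compound 2 to compound 4 (0.23 log units; within the scatter) and a 1.1-fold lower number from compound 1 to compound 4 (0.05 log units; within the scatter) as the remaining steps. The compounds shown leave open whether a larger group here, such as an amine or a carboxylic acid, would move the number beyond the scatter. No measurement offered here explains these small steps.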